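The source may report more compounds than this note shows. Statements on the series, on what has been measured and on what is new or still open speak of the compounds shown alone.

Compound 1, `O=S(=O)(/C=C/c1ccccn1)c1cccc(F)c1`, was tested in an assay on U2OS cells for activation of nuclear factor erythroid 2-related factor 2 (Homo sapiens), read by beta-arrestin recruitment, with a stated time of 6 h (a higher number here means that more compound is needed for the effect, a lower number that less compound is needed), where compound 1 gives 1680 nM. Compound 2, `O=S(=O)(/C=C/c1ccc(Cl)cn1)c1cccc(F)c1`, carries one additional group on the same core, and in this assay compound 2 gives 2500 nM. The change between them is chloro in place of hydrogen on an aromatic carbon, and it brought a 1.5-fold higher number from compound 1 to compound 2 (0.17 log units; within the scatter).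

Compound 3, `O=S(=O)(/C=C/c1cccnc1)c1cccc(Cl)c1`, is built on a different core; how the two cores differ is not broken down here. In this assay compound 3 gives 3520 nM, the highest of the three numbers. Its gap to compound 2 lies within the scatter, while its gap to compound 1 lies beyond it.

Compound 4, `O=S(=O)(/C=C/c1cccnc1Cl)c1cccc(Cl)c1`, has not yet been measured in this assay. It differs from compound 3 by chloro in place of hydrogen on an aromatic carbon. Among the compounds with values here, this is the same kind of change as the one from compound 1 to compound 2, but not the same change: in compound 2 the chloro sits two atoms from the ring nitrogen and para to a large group, whereas in compound 4 it sits next to the ring nitrogen and ortho to a large group. Within the data shown here, the one precedent available, a 1.5-fold higher number from compound 1 to compound 2 (0.17 log units; within the scatter), stayed within the scatter. On that single precedent, compound 4 is expected to show a 1.3-fold higher number from compound 3 to compound 4 (0.11 log units; within the scatter). Because compound 3 gives 3520 nM, compound 4 is expected to give 4500 nM. Among the measured compounds shown here, the estimated range for compound 4 runs from 2000 nM to 10000 nM, widened to allow for the different placement of the chloro and for the fact that only one comparable step is known.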

Compound 4, half-maximal effective concentration: 213 nM
Compound 4: middle estimate off by 21-fold (1.32 log units), on the high side; measured number below the stated range.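

In this assay, placing chloro in place of hydrogen on an aromatic carbon, next to the ring nitrogen and ortho to a large group, brought a 17-fold lower number from compound 3 to compound 4 (1.22 log units; beyond the scatter). This means that a change of the same kind did not carry over from one core to the other at the same size, so the small step seen earlier gave no safe guide to this one: the same change on two cores in this assay, a 1.5-fold higher number (0.17 log units; within the scatter) from compound 1 to compound 2 and a 17-fold lower number (1.22 log units; beyond the scatter) from compound 3 to compound 4, 25-fold (1.39 log units) apart, beyond the scatter of two such steps. It does not show why the two steps differ, since the core and the place of the chloro both differ between the two pairs, and two steps cannot separate these two differences or establish a rule for any other core in the series.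

The compounds shown leave open whether a chloro placed next to the ring nitrogen and ortho to a large group on the core of compound 1 would also give a large step toward a lower number, which would help separate the effect of the place from that of the core. They also leave open whether the large step belongs to chloro itself, or whether a methyl, a methoxy or an amine on that same aromatic carbon of compound 3 would give a similar one.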